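Spirohydantoin quinolines in the maximal electroshock test

This account rests on a few compounds, and the source may have more. Where it says the series, first, only, none or still open, it means among the compounds named here.

Measured compounds:
compound 1, `CC(C)N1C(=O)NC2(CC2c2ccc3cccc(OCc4ccccc4)c3n2)C1=O`: 300 mg/kg
compound 2, `O=C1NC2(CC2c2ccc3cccc(OCc4ccccc4)c3n2)C(=O)N1C1CCCCC1`: 300 mg/kg

Compound 1 carries an isopropyl group on the amide-type nitrogen in the five-membered ring, and in a functional assay on the whole organism (strain Kunming) with Mus musculus as the target, in the maximal electroshock model, with a stated time of 0.5 h (on this read-out lower numbers stand for an effect already at smaller amounts and higher numbers for an effect only at larger amounts of compound), compound 1 gives 300 mg/kg. Compound 2 is the cyclohexyl counterpart, and in this assay compound 2 gives 300 mg/kg. The only step so far, no change at the digits printed from compound 1 to compound 2 (within the scatter), shows that exchanging isopropyl for cyclohexyl on that nitrogen leaves the result where it was; compound 2 therefore stands level with compound 1 on the numbers shown.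

Compound 3, `CCCCN1C(=O)NC2(CC2c2ccc3cccc(OCc4ccccc4)c3n2)C1=O`, is the next member. Its difference from compound 2 is butyl in place of cyclohexyl on an amide-type nitrogen in a ring, again a change confined to the group on the amide-type nitrogen in the ring. Among the measured compounds shown here, the one step that bears on it, no change at the digits printed from compound 1 to compound 2 (within the scatter), was flat, so a butyl group at the same place is expected to give no step beyond the scatter; the expected step is no change at the digits printed from compound 2 to compound 3 (within the scatter). In this assay compound 3 is therefore estimated at 300 mg/kg, within a range of 100 mg/kg to 600 mg/kg, pending the measurement.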

Compound 3, minimum effective dose: 300 mg/kg
The estimate for compound 3 equals the measured number at the digits printed; measured number inside the range.
By their numbers in this assay, from the lowest: compounds 1, 2 and 3 (each within the scatter of the next).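

In this assay, exchanging the cyclohexyl group for butyl on the amide-type nitrogen in a ring gives no change at the digits printed from compound 2 to compound 3 (within the scatter), so replacing a six-membered carbon ring with an open chain of 4 heavy atoms does not shift the reading at this position. Exchanging isopropyl for butyl at the same nitrogen gives no change at the digits printed from compound 1 to compound 3 (within the scatter), which extends the flat result from a single exchange to all three groups, one open-chain group differing from both a ring and the isopropyl group. No supporting data are available to explain why these exchanges leave the minimum effective dose unchanged.

The compounds shown leave open whether a group carrying a terminal amine or a carboxylic acid, a longer chain such as octyl, or a benzyl group on this nitrogen would move the reading beyond the scatter. They also leave open whether the amide-type nitrogen bearing only a hydrogen would read the same, and whether changes elsewhere on the shared core, such as replacing the benzyloxy group, would have any larger effect.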